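The source may report more compounds than this note shows. Statements on the series, on what has been measured and on what is new or still open speak of the compounds shown alone.

Compound 1, with the structure `Cc1ccccc1-c1nn(-c2ccc(F)cc2F)cc1CNCCN1CCCCC1`, has been examined in an ADME assay on Huh-7 cells (Homo sapiens) for cytotoxicity; a lower number here means that less compound is tolerated, a higher number that more compound is tolerated. In this assay compound 1 gives only a limit, > 20000 nM, so no number is known for it. Two close relatives have been run alongside it. Compound 2, built as `Cc1ccccc1-c1nn(-c2ccc(F)c(F)c2)cc1CNCCN1CCN(C)CC1`, likewise stops at a limit, > 20000 nM. Compound 3, built as `Cc1ccccc1-c1nn(-c2ccc(F)cc2F)cc1CN1CCC(N2CCCCC2)CC1`, also stands at a limit, > 20000 nM. All three values therefore sit at the limit of > 20000 nM in this assay, at which 3 of the 3 values shown sit, and none of these compounds has been seen to harm the cells within the tested range.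

Compound 4, with the structure `Cc1ccccc1-c1nn(-c2ccc(F)cc2F)cc1CNCCN(C)C`, is the next to be measured. It differs from compound 1 in a single place: dimethylamino in place of piperidin-1-yl on a saturated chain carbon, two bonds along the chain from an amine nitrogen. Among the measured compounds no step in tolerated concentration is known for any structural change, as each of the three values is a limit rather than a number. For the move to compound 4 in this assay the expected change is a step that the limit leaves unreadable from compound 1 to compound 4, that is, none beyond the scatter. Compound 4 is accordingly estimated at 30000 nM, with a plausible range from 10000 nM to 90000 nM, and most likely this assay will again report only a limit for it.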

Compound 4, half-maximal cytotoxic concentration: > 20000 nM
Compound 4: no number, only a limit; the forecaster's own chance of this, stated with the estimate: 85%; the middle value does not contradict the limit.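

Compound 4 also gives only a limit in this assay, so no step can be read from compound 1 to compound 4, since every compound shown stops at the same limit: the limit of > 20000 nM in this assay, at which 4 of the 4 values shown sit. Still open is what concentration of any of these compounds harms the cells, and whether replacing piperidin-1-yl with dimethylamino changes it.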